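Thiourea series: working notes

The compounds below may be only part of what the source reports. "The series", "measured", "known", "first", "only" and "open" are said of these compounds alone.

Measured so far:
compound 1 `CC[C@H]1CC[C@H](c2ccc(NC(=S)Nc3cccc(C(F)(F)F)c3)cc2)CC1`, 10000 nM
compound 2 `O=C(NC(=S)Nc1cccc(C(F)(F)F)c1)[C@H]1C[C@@H]2CC[C@H]1C2`, 20000 nM

In an ADME assay on Vero 76 cells (Chlorocebus sabaeus) for cytotoxicity, read by crystal violet staining, with a stated time of 96 h (a higher number here means that more compound is tolerated, a lower number that less compound is tolerated), compound 1 gives 10000 nM. Compound 1 stands at the lowest of the two numbers measured; the nearest is compound 2 with 20000 nM, and the gap between the two falls within the usual scatter, so the two values cannot be ordered.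

Compound 3 `FC(F)(F)c1cccc(NC(=S)Nc2ccccc2)c1` has not been measured in this assay. It differs from compound 1 in one place: hydrogen in place of 4-ethylcyclohexyl on an aromatic carbon. The trifluoromethylphenyl thiourea part of compound 1 is kept; only the 4-ethylcyclohexyl on an aromatic carbon is replaced by hydrogen.

Among the measured compounds shown here, no step between two measured compounds of this kind is available, so the expectation rests on the structural change alone. Loss of the 4-ethylcyclohexyl removes much of the molecule, and the step of a 3.0-fold higher number from compound 1 to compound 3 (0.48 log units; beyond the scatter) is expected to be upward, somewhat beyond the scatter, meaning more compound tolerated. Compound 3 is estimated at 30000 nM, with a range of 10000 nM to 100000 nM.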

Compound 3, half-maximal cytotoxic concentration: 39000 nM
For compound 3 the middle estimate is 1.3-fold (0.11 log units) below the measured one; the measured number falls inside the stated range.
By their numbers in this assay, from the lowest: compounds 1, 2 and 3 (each within the scatter of the next, the first and the last beyond it).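

In this assay, the series now has its first comparison of two compounds differing in one place: hydrogen in place of 4-ethylcyclohexyl on an aromatic carbon gives a 3.9-fold higher number from compound 1 to compound 3 (0.59 log units; beyond the scatter). The group at this position, para to a large group, therefore has a measurable bearing on how much compound is tolerated, and the bare aromatic carbon is the more tolerated of the two forms, though the step is modest. No measured evidence bears on the reason for this step, so this single pair records only the direction and size of the change.

What the compounds shown leave open is whether the step belongs to the six-membered ring or to its ethyl group, since both leave together, and a plain cyclohexyl or a short chain such as ethyl at this place would separate the two. Also open, from the compounds shown here alone, is where a methyl, an amine or a carboxylic acid on this aromatic carbon would fall relative to compound 1 and compound 3.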